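Series notes: 1H-pyrazol-1-yl in place of bromo

The source may hold more compounds than are shown below. What is called first, only, known or untested is meant among the compounds shown, and "the series" means these compounds.

Compound 1 `NC1CCC(Nc2nc(NCc3ccc(Br)cc3)c3ncn(C4CCCC4)c3n2)CC1` is the reference point of this set. Going by the values given here, in a functional assay on G-361 cells (Homo sapiens) for inhibition, with a stated time of 72 h (on this read-out higher numbers stand for weaker inhibition and lower numbers for stronger inhibition), compound 1 gives 1480 nM, the highest of the three numbers so far, though its steps to the other two both fall within the scatter. Compound 2 `NC1CCC(Nc2nc(NCc3ccc(-c4ccccc4)cc3)c3ncn(C4CCCC4)c3n2)CC1` gives 1020 nM and compound 3 `NC1CCC(Nc2nc(NCc3ccc(-c4cccc(F)c4)cc3)c3ncn(C4CCCC4)c3n2)CC1` gives 815 nM. The two measured steps from the reference are a 1.5-fold lower number from compound 1 to compound 2 (0.16 log units; within the scatter) and a 1.8-fold lower number from compound 1 to compound 3 (0.26 log units; within the scatter); the further step a 1.3-fold lower number from compound 2 to compound 3 (0.10 log units; within the scatter) is likewise small.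

Compound 4 `NC1CCC(Nc2nc(NCc3ccc(-n4cccn4)cc3)c3ncn(C4CCCC4)c3n2)CC1` is not yet measured. It differs from compound 1 by 1H-pyrazol-1-yl in place of bromo on an aromatic carbon. Among the compounds with values here, the steps that bear on it are those in which bromo was also exchanged for a ring at the same place, from compound 1 to compound 2 and from compound 1 to compound 3; both gave lower numbers of a size that stays within the scatter. Within the data shown here, no measured pair informs on a five-membered aromatic ring with two hetero atoms at this place, so the expectation rests on those two steps alone.

The expected step is therefore a 1.6-fold lower number from compound 1 to compound 4 (0.19 log units; within the scatter), in the direction of a lower number but not beyond the scatter. Compound 4 is estimated at 950 nM, with a range from 450 nM to 2000 nM.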

Compound 4, half-maximal inhibitory concentration: 220 nM
Compound 4: the middle estimate sits 4.3-fold (0.64 log units) above what was measured, outside the stated range (below it).
By their numbers in this assay, from the lowest: compound 4; then compounds 3, 2 and 1 (each within the scatter of the next).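

Going by these compounds alone, at this place on the six-membered aromatic ring, 1H-pyrazol-1-yl in place of bromo gives the first step in this assay that goes beyond the scatter, with a 6.7-fold lower number from compound 1 to compound 4 (0.83 log units; beyond the scatter) as the measure of that change. The earlier exchanges of bromo for a ring did not show this, and the new ring also stands clear of the two biaryl groups, with a 4.6-fold lower number from compound 2 to compound 4 (0.67 log units; beyond the scatter) against phenyl and a 3.7-fold lower number from compound 3 to compound 4 (0.57 log units; beyond the scatter) against 3-fluorophenyl, so compounds 2 and 3 show that a ring in place of bromo is not enough on its own to produce such a step. Nothing measured here accounts for the step.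

Open, as far as these compounds go, is whether the step belongs to 1H-pyrazol-1-yl in particular or extends to other five-membered aromatic rings at this place, such as imidazol-1-yl, 1,2,3-triazol-1-yl or thiazolyl. Also open, from the compounds shown here alone, is how a methyl group on the pyrazole ring, or a pyridyl ring or a small amine in its place, would read in this assay, and whether the same step holds with other groups on the shared core.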